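Ring substituent and rat half-life in the series

The source may hold more compounds than are shown below. What is called first, only, known or untested is meant among the compounds shown, and "the series" means these compounds.

Compound 1 `Cc1cc(C)c(NC(=O)c2sccc2S(=O)(=O)Nc2onc(C)c2Cl)c(C)c1` is the parent of this set, with hydrogen at the aromatic carbon under study. Going by the values given here, in an in vivo ADME assay on the whole organism for pharmacokinetics, with Rattus norvegicus as the target (a lower number here means that the compound disappears faster, a higher number that the compound lasts longer), compound 1 gives 2.5 h, the second highest of the three numbers so far. Compound 2 `Cc1cc(C)c(N(C)C)c(C)c1NC(=O)c1sccc1S(=O)(=O)Nc1onc(C)c1Cl` gives 1 h in this assay, and compound 3 `Cc1cc(C)c(NC(=O)c2sccc2S(=O)(=O)Nc2onc(C)c2Cl)c(C)c1O` gives 7.3 h. The two measured steps from compound 1 both replace hydrogen at the same aromatic carbon and pull in opposite directions: a 2.5-fold lower number from compound 1 to compound 2 (0.40 log units; beyond the scatter), whereas a 2.9-fold higher number from compound 1 to compound 3 (0.47 log units; beyond the scatter); between the two substituted compounds, a 7.3-fold higher number from compound 2 to compound 3 (0.86 log units; beyond the scatter).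

Compound 4 `Cc1cc(C)c(NC(=O)c2sccc2S(=O)(=O)Nc2onc(C)c2Cl)c(C)c1CO` carries the change (hydroxymethyl in place of hydrogen on an aromatic carbon). Both measured steps bear on it, as each places a group on this carbon, yet they disagree in direction, so no firm trend exists with one compound on either side. The hydroxy step to compound 3 looks the nearer comparison by name of the entering group, the dimethylamino step to compound 2 the more distant one. Compound 4 is therefore expected at 3.5 h in this assay, with a range of 1.5 h to 8 h. The step expected is a 1.4-fold higher number from compound 1 to compound 4 (0.15 log units; within the scatter), a slight rise that may not clear the scatter.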

Compound 4, half-life: 1.4 h
Estimate against measurement, compound 4: 2.5-fold (0.40 log units) above; measured number outside the range, below it.
By their numbers in this assay, from the lowest: compounds 2, 4 and 1 (each within the scatter of the next, the first and the last beyond it); then compound 3.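

In this assay, hydroxymethyl on this aromatic carbon does not separate from the neighbouring entries in the series: a 1.8-fold lower number from compound 1 to compound 4 (0.25 log units; within the scatter) and a 1.4-fold higher number from compound 2 to compound 4 (0.15 log units; within the scatter) both leave compound 4 within the scatter of compounds 1 and 2. Hydroxy alone stands apart at this carbon, with a 5.2-fold lower number from compound 3 to compound 4 (0.72 log units; beyond the scatter) showing that the long half-life of compound 3 does not carry over to hydroxymethyl, so a group containing oxygen is not enough for it, and compound 4 goes against any such reading. Nothing at hand accounts for the gap between hydroxy and hydroxymethyl.

Open, from the compounds shown here alone, is whether the long half-life of compound 3 is confined to hydroxy directly on the aromatic carbon. Methoxy, aminomethyl, a carboxylic acid or a longer chain ending in hydroxy at this carbon would test how narrow that result is.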